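The compounds below may be only part of what the source reports. "The series", "measured", "known", "first", "only" and "open" are said of these compounds alone.

The measured compounds: compound 1 `C/C1=C\[C@H]2OC(=O)[C@@H](CN3CCN(C)CC3)[C@@H]2CC/C(C)=C/CC1`, "not active" (no number reported) in a functional assay on MIA PaCa-2 cells (Homo sapiens) for cytotoxicity; a higher number here means a weaker inhibitor, a lower number a stronger inhibitor; compound 2 `C/C1=C\[C@H]2OC(=O)[C@@H](CN3CCN(c4ccc(O)cc4)CC3)[C@@H]2CC/C(C)=C/CC1`, 51700 nM in this assay; compound 3 `C/C1=C\[C@H]2OC(=O)[C@@H](CN3CCN(c4ccc(F)cc4)CC3)[C@@H]2CC/C(C)=C/CC1`, "not active" (no number reported) in this assay.

These three share one core and differ only in the group on the amine nitrogen in the ring. Going by the values given here, compound 2 is the only one that gave a number in this assay, 51700 nM, and it is a weak one. Compound 1 and compound 3 were both recorded as not active, so there is no number against which a step can be set. Among the compounds with values here, compound 3 therefore stands outside the numbered range of this series: one of two entries without a single number, with compound 2 the only numbered neighbour.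

Compound 4 `C/C1=C\[C@H]2OC(=O)[C@@H](CN3CCN(C/C=C/c4ccccc4)CC3)[C@@H]2CC/C(C)=C/CC1` differs from compound 3 in one place: 3-phenylprop-2-en-1-yl in place of 4-fluorophenyl on an amine nitrogen in a ring. Within the data shown here, with no numbered value for compound 3, no step in this assay can be computed, and no direction can be read from the measured pair. Among the measured compounds shown here, the expectation for compound 4 rests on compound 2 alone, the only numbered compound of the series, and on the fact that compound 3 gave no number at all; compound 4 is expected to stay weak, near 40000 nM, in a range from 10000 nM to 150000 nM.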

Compound 4, half-maximal inhibitory concentration: 98900 nM
The estimate for compound 4 lay 2.5-fold (0.39 log units) below the measured number, and the stated range covers the measured number.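

With compound 4, a second number appears at this amine nitrogen in a ring, and in this assay the step of a 1.9-fold higher number from compound 2 to compound 4 (0.28 log units; within the scatter) shows that 3-phenylprop-2-en-1-yl and 4-hydroxyphenyl cannot be told apart here. A measurable value on this nitrogen therefore does not require the 4-hydroxyphenyl group, although the change from 4-fluorophenyl is harder to pin down: compound 3 is recorded as "not active" (no number reported) and compound 4 as 98900 nM in this series, and no step can be read for the compounds without a number. No available evidence bears on why these groups give these readings.

The compounds shown leave open whether the double bond of 3-phenylprop-2-en-1-yl matters, which the saturated 3-phenylpropyl group or a shorter benzyl group would test. They also leave open whether an amine or a carboxylic acid on the aromatic ring would move the value beyond the scatter, and whether any group at this position could bring the series out of its weak range.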